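The source may hold more compounds than are shown below. What is called first, only, known or untested is meant among the compounds shown, and "the series" means these compounds.

Compounds measured so far:
Compound 1, `CC(C)S(=O)(=O)Nc1cccc(C2CCN(Cc3cn(-c4ccccc4)nn3)CC2)c1`: in an assay on membranes from HEK293 cells for displacement of a labelled ligand from Sigma non-opioid intracellular receptor 1 (Homo sapiens), read by scintillation counting, with a stated time of 120 min (a lower number here means a stronger inhibitor, a higher number a weaker inhibitor), compound 1 gives < 100 nM, a limit of the assay and not a number.
Compound 2, `Oc1cccc(C2CCN(Cc3cn(-c4ccccc4)nn3)CC2)c1`: in this assay compound 2 gives < 100 nM, likewise a limit.

Compound 2 thus stands at the limit of < 100 nM in this assay, at which 2 of the 2 values shown sit, without a number of its own. Among the compounds with values here, the one step between measured compounds, a step that the two limits leave unreadable from compound 1 to compound 2, cannot be read, so it sets no scale for what follows. Compound 3, `CC(=O)Oc1cccc(C2CCN(Cc3cn(-c4ccccc4)nn3)CC2)c1`, differs from compound 2 by acetyl in place of hydrogen on an oxygen on an aromatic ring. No measured step bears directly on this change, and the single step shown gives no size at all, so the expectation rests on the two limits and the change itself. Compound 3 is expected to move by a step that the limit leaves unreadable from compound 2 to compound 3, a small weakening that may well stay inside the usual scatter. Compound 3 is accordingly estimated at 60 nM, with a range from 8 nM to 400 nM.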

Compound 3, inhibition constant: < 100 nM
Compound 3: only a limit was reported (the forecaster's own chance of this, stated with the estimate: 40%); the middle value is on the limit's open side.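

Within the data shown here, no step between compound 1, compound 2 and compound 3 can be read, because each gives only a limit and not a number: the limit of < 100 nM in this assay, at which 3 of the 3 values shown sit.

The compounds shown leave open how far hydroxy, acetoxy and (isopropylsulfonyl)amino differ, if at all, in this assay once actual numbers replace the limits.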